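Chloro in Place of Fluoro, Read by Paw Edema

This account rests on a few compounds, and the source may have more. Where it says the series, first, only, none or still open, it means among the compounds named here.

Compound 1 `O=CN1N=C(c2ccc(F)cc2)CC1c1cn(-c2ccccc2)nc1-c1ccc(Cl)c(Cl)c1` was tested in a functional assay on the whole organism (strain Wistar) for inhibition, with Rattus norvegicus as the target, read by paw edema, with a stated time of 30 min, at a dose of 50 mg/kg by the oral route (on this read-out higher numbers stand for more inhibition at the one dose given (going by the name of the read-out) and lower numbers for less inhibition), where compound 1 gives 37.2%. Among the measured compounds shown here, the only other number comes from compound 2 `Fc1ccc(C2=NN(c3ccccc3)C(c3cn(-c4ccccc4)nc3-c3ccc(Cl)c(Cl)c3)C2)cc1`, which in this assay gives 44.7%; the step of a number 7.5 percentage points higher from compound 1 to compound 2 (within the scatter) is within the scatter, so the two compounds sit together. Compound 3 `O=CN1N=C(c2ccc(Cl)cc2)CC1c1cn(-c2ccccc2)nc1-c1ccc(Cl)c(Cl)c1` differs from compound 1 by chloro in place of fluoro on an aromatic carbon. For the measured compounds named here, no measured step touches this group, and the one step on hand, a number 7.5 percentage points higher from compound 1 to compound 2 (within the scatter), concerns another place and stayed within the scatter. Compound 3 is therefore expected to move by a number 2.8 percentage points higher from compound 1 to compound 3 (within the scatter) in this assay, no more than the scatter. Compound 3 is estimated at 40%, within 25% to 55%.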

Compound 3, a percentage reported as inhibition, in the whole organism at one dose (the size of the read-out at that dose, not a potency): 35.1%
Estimate against measurement, compound 3: 4.9 percentage points above; the range from low to high includes it.
By their numbers in this assay, from the lowest: compounds 3, 1 and 2 (each within the scatter of the next).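

In this assay, among the compounds shown here, the change from 4-fluorophenyl to 4-chlorophenyl gives a number 2.1 percentage points lower from compound 1 to compound 3 (within the scatter), the first measured step at this place on the aromatic ring. One halogen thus stands in for the other here without a step beyond the scatter. No measurement on hand bears on what lies behind this result.

As far as these compounds go, whether a methoxy group or an amine at this same position would give a step beyond the scatter stays open. Also open, from the compounds shown here alone, is whether chloro in place of fluoro would read the same in the setting of compound 2.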